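Swapping phenyl for pyridin-2-yl on a thioether sulfur

A few compounds are considered here, and "the series" means these few. Any claim that something is new, unique, unknown or untested is made for them only; others in the source may bear on it.

Among the measured compounds shown here, compound 1 `C=C1CC[C@@H]2[C@](C)(CO)[C@H](O)CC[C@@]2(C)[C@@H]1CC(Sc1ccccc1)C1=CCOC1=O` is assessed in a functional assay on PC-3 cells (Homo sapiens) for inhibition, read by MTT assay, with a stated time of 48 h (a lower number here means a stronger inhibitor, a higher number a weaker inhibitor), where compound 1 gives 14000 nM, one of only two numbers so far, with compound 2 `C=C1CC[C@@H]2[C@](C)(CO)[C@H](O)CC[C@@]2(C)[C@@H]1CC(Sc1ccc(OC)cc1)C1=CCOC1=O` within the scatter of it at 15000 nM. Along the path from compound 1 to compound 2 came a 1.1-fold higher number from compound 1 to compound 2 (0.03 log units; within the scatter), a change at the aromatic ring that barely registered. Compound 3 `C=C1CC[C@@H]2[C@](C)(CO)[C@H](O)CC[C@@]2(C)[C@@H]1CC(Sc1ccccn1)C1=CCOC1=O` differs from compound 1 by pyridin-2-yl in place of phenyl on a sulfur. For the measured compounds named here, only that methoxy step bears on this change, and it stayed within the scatter. The expected step is therefore a 1.1-fold higher number from compound 1 to compound 3 (0.03 log units; within the scatter), none beyond the scatter. Compound 3 is thus estimated to give 15000 nM, with a range from 7000 nM to 32000 nM.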

Compound 3, half-maximal inhibitory concentration: 18000 nM
Compound 3: middle estimate off by 1.2-fold (0.08 log units), on the low side; the range from low to high includes it.
By their numbers in this assay, from the lowest: compounds 1, 2 and 3 (each within the scatter of the next).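

In this assay, pyridin-2-yl in place of phenyl on the sulfur gives a 1.3-fold higher number from compound 1 to compound 3 (0.11 log units; within the scatter), and pyridin-2-yl in place of 4-methoxyphenyl gives a 1.2-fold higher number from compound 2 to compound 3 (0.08 log units; within the scatter). Among the compounds shown here, the earlier pair showed only that adding a methoxy group to the ring left the number within the scatter; these steps show the same for a ring nitrogen that adds a hydrogen-bond acceptor. No measured evidence here accounts for this result. Still open, as far as these compounds go, is whether an amine or carboxylic acid on this ring, or a saturated alkyl chain on the sulfur in its place, would move the number beyond the scatter.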